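Stereocentre configuration dropped at the chain carbon of compound 3

A few compounds are considered here, and "the series" means these few. Any claim that something is new, unique, unknown or untested is made for them only; others in the source may bear on it.

Compound 1 `Cc1cccc(C)c1-c1cccc(COc2ccc(CCC(=O)O)cc2)c1` gives 8 nM in a functional assay on cells for agonist activity at Free fatty acid receptor 1 (Homo sapiens), read by calcium flux; a higher number here means that more compound is needed for the effect, a lower number that less compound is needed. Compound 2 `Cc1cccc(C)c1-c1cccc(COc2ccc(CCC(=O)O)s2)c1` gives 32 nM in this assay. Compound 3 `CC#C[C@@H](CC(=O)O)c1ccc(OCc2cccc(-c3c(C)cc(OCCCS(C)(=O)=O)cc3C)c2)s1` gives 81 nM in this assay, the highest of the three numbers; its nearest neighbour is compound 2 and compound 1 lies furthest from it, both gaps beyond the scatter. Compound 4 `CC#CC(CC(=O)O)c1ccc(OCc2cccc(-c3c(C)cc(OCCCS(C)(=O)=O)cc3C)c2)s1` is the next step in the series. The change from compound 3 is the two compounds have the same atoms and bonds; at least one stereo element is drawn with a configuration in one of them and without one in the other: 1 of 1 stereo elements differ; a stereocentre at a saturated chain carbon is drawn R in compound 3 and without a configuration in compound 4. For the measured compounds named here, no measured pair differs in this way, so the size of the step rests on no precedent; the expectation is a modest rise in the number, a 1.9-fold higher number from compound 3 to compound 4 (0.27 log units; within the scatter), at the edge of the scatter rather than a large shift. Compound 4 is expected to give about 150 nM, with a range from 70 nM to 320 nM.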

Compound 4, half-maximal effective concentration: 240 nM
Compound 4: the middle estimate sits 1.6-fold (0.20 log units) below what was measured; low and high end bracket the measured number.
By their numbers in this assay, from the lowest: compound 1; then compound 2; then compound 3; then compound 4.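

In this assay, the configuration drawn at the saturated chain carbon matters to the number: a 3.0-fold higher number from compound 3 to compound 4 (0.47 log units; beyond the scatter). For the compounds shown here, the earlier compounds carry no stereocentre, so this is the first indication that this carbon is sensitive to configuration, with compound 3, drawn R, giving the lower number. The only structural difference on record is in the drawing: the fact that one of compounds 3 and 4 is drawn with a defined configuration and the other without, at the place where they differ

The compounds shown leave open how the S form alone behaves. Also open, from the compounds shown here alone, is whether a cyclopropyl group at this carbon would show the same dependence on configuration.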